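This account rests on a few compounds, and the source may have more. Where it says the series, first, only, none or still open, it means among the compounds named here.

Measured so far in an ADME assay on BEAS-2B cells (Homo sapiens) for cytotoxicity, read by MTT assay, with a stated time of 72 h; on this read-out lower numbers stand for stronger inhibition of growth and higher numbers for weaker inhibition of growth:
- compound 1, `N#C[Se]c1ccc(NC(=O)Oc2ccc(F)cc2)cc1`: 45600 nM
- compound 2, `Cc1ccc(OC(=O)Nc2ccc([Se]C#N)cc2)cc1`: 15300 nM

Compound 2 holds the lowest of the two numbers in this assay; its nearest neighbour is compound 1, separated by a 3.0-fold lower number from compound 1 to compound 2 (0.47 log units; beyond the scatter). The unmeasured compound 3, `N#C[Se]c1ccc(NC(=O)Oc2ccc(Cl)cc2)cc1`, differs from compound 2 by chloro in place of methyl on an aromatic carbon. For the measured compounds named here, the only step that bears on this position is a 3.0-fold lower number from compound 1 to compound 2 (0.47 log units; beyond the scatter), fluoro giving way to methyl. Going by the values given here, no measured pair sets chloro against methyl, so compound 3 is expected to fall between the two measured values, nearer compound 2. Compound 3 is expected at 25000 nM, with a range of 10000 nM to 60000 nM, which means an expected 1.6-fold higher number from compound 2 to compound 3 (0.21 log units; within the scatter).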

Compound 3, concentration for total growth inhibition: 38000 nM
For compound 3 the middle estimate is 1.5-fold (0.18 log units) below the measured one, within the range that was stated.
By their numbers in this assay, from the lowest: compound 2; then compounds 3 and 1 (each within the scatter of the next).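

In this assay, chloro in place of methyl on an aromatic carbon para to a large group gives a step beyond the scatter (a 2.5-fold higher number from compound 2 to compound 3 (0.40 log units; beyond the scatter)), so methyl now stands apart from two halogens rather than one. Chloro in place of fluoro stays within the scatter (a 1.2-fold lower number from compound 1 to compound 3 (0.08 log units; within the scatter)), and these two halogens cannot be told apart here. No measurement available accounts for the separation of methyl from them.

The compounds shown leave open whether an ethyl or methoxy group at this place would side with methyl or with the two halogens. As far as these compounds go, whether an amine there would differ from all three also remains open.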